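This account rests on a few compounds, and the source may have more. Where it says the series, first, only, none or still open, it means among the compounds named here.

Compound 1, `COc1cccc(/C=C/C(=O)c2sc(Nc3ccccc3)nc2C)c1`: in a functional assay on PC-3 cells (Homo sapiens) for cytotoxicity, read by MTT assay (on this read-out lower numbers stand for stronger inhibition and higher numbers for weaker inhibition), compound 1 gives > 25000 nM, which is a limit of the assay and not a number.
Compound 2, `Cc1nc(Nc2ccccc2)sc1C(=O)/C=C/c1ccccc1`: in this assay compound 2 gives > 25000 nM, again a limit.
Compound 3, `Cc1nc(Nc2ccccc2)sc1C(=O)/C=C/c1ccccc1Cl`: in this assay compound 3 gives > 25000 nM, also a limit.

Compound 1 therefore stands nowhere in particular among the numbers shown: all three values sit at the same limit, (the limit of > 25000 nM in this assay, at which 3 of the 3 values shown sit), and no order among the three compounds can be read. Compound 4, `COc1cccc(/C=C/C(=O)c2sc(Nc3cccc(Cl)c3)nc2C)c1`, differs from compound 1 by chloro in place of hydrogen on an aromatic carbon. The closest measured change is a step that the two limits leave unreadable from compound 2 to compound 3, where chloro also replaced hydrogen on an aromatic carbon, though on the other aryl ring of the shared core; the remaining steps, a step that the two limits leave unreadable from compound 1 to compound 2 and a step that the two limits leave unreadable from compound 1 to compound 3, concern that same other ring and are likewise unreadable. For the measured compounds named here, none of these measured steps gives a size, so no step of readable size in either direction is expected for compound 4 in this assay. The most likely outcome for compound 4 is estimated to be a step that the limit leaves unreadable from compound 1 to compound 4, which would again leave it at the limit. Compound 4 is expected to give about 40000 nM, within a range of 15000 nM to 100000 nM.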

Compound 4, half-maximal inhibitory concentration: > 25000 nM
Compound 4 gave a limit, no number (the forecaster's own chance of this, stated with the estimate: 80%); the middle value is on the limit's open side.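

In this assay, for the compounds shown here, compound 4 gives > 25000 nM, a limit and not a number, so no step from compound 1 to compound 4 can be read, and compounds 1, 2, 3 and 4 remain unordered: the limit of > 25000 nM in this assay, at which 4 of the 4 values shown sit. The compounds shown leave open whether chloro in place of hydrogen on either aromatic ring changes the value at all.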